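The compounds below may be only part of what the source reports. "The series", "measured", "known", "first", "only" and "open" are said of these compounds alone.

Measured so far:
- compound 1 `COc1ccc(-c2cc(C(=O)/C=C/c3cccc(OC)c3OC)ccc2N)cc1OC`: 5360 nM
- compound 2 `COc1ccc(/C=C/C(=O)c2ccc(N)c(-c3ccc(OC)c(OC)c3)c2)c(OC)c1`: 2130 nM

Not yet measured:
- compound 3 `COc1cccc(/C=C/C(=O)c2ccc(N)c(-c3ccc(F)cc3)c2)c1OC`

In a functional assay on HepG2 cells (Homo sapiens) for cytotoxicity, read by sulforhodamine B assay, with a stated time of 48 h (a lower number here means a stronger inhibitor, a higher number a weaker inhibitor), compound 1 holds the higher of the two numbers. Going to compound 3, 4-fluorophenyl replaces 3,4-dimethoxyphenyl on an aromatic carbon (4-fluorophenyl in place of 3,4-dimethoxyphenyl on an aromatic carbon). Among the compounds with values here, the only measured step, a 2.5-fold lower number from compound 1 to compound 2 (0.40 log units; beyond the scatter), is modest and concerns a different place, the 2,3-dimethoxyphenyl group, which compound 3 keeps. Within the data shown here, it therefore bears only loosely on this exchange and gives no direction, and no measured step covers the exchange itself. A modest change at most is expected, with no clear shift beyond the scatter. The expected step is a 1.2-fold lower number from compound 1 to compound 3 (0.08 log units; within the scatter). For compound 3 the estimated value is 4500 nM, with an expected range of 1500 nM to 13000 nM.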

Compound 3, half-maximal inhibitory concentration: 7370 nM
Estimate against measurement, compound 3: 1.6-fold (0.21 log units) below, and the stated range covers the measured number.
By their numbers in this assay, from the lowest: compound 2; then compounds 1 and 3 (each within the scatter of the next).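

In this assay, 4-fluorophenyl in place of 3,4-dimethoxyphenyl, on the aromatic carbon ortho to an amino group, gives a 1.4-fold higher number from compound 1 to compound 3 (0.14 log units; within the scatter). For this pair, the two methoxy groups of the leaving group are therefore not required to keep the number at this level, and the position accepts a smaller aryl group without a step beyond the scatter. No supporting data bear on why this is so.

Still open, going by these compounds, is whether a carboxylic acid or a dimethylamino group on that phenyl ring would move the number beyond the scatter. Also open, on these data alone, is whether 4-fluorophenyl behaves the same alongside the 2,4-dimethoxyphenyl group of compound 2.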